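Anilide in place of the acid on a bis-thioacetate chain

This account rests on a few compounds, and the source may have more. Where it says the series, first, only, none or still open, it means among the compounds named here.

For the measured compounds named here, compound 1 `CC(=O)SCCC(CCCCC(=O)O)SC(C)=O` is the only compound in this set with a number to its name. In a functional assay on HO8910 cells (Homo sapiens) for inhibition, read by MTT assay, with a stated time of 24 h, tested at 10 ug/mL (a lower number here means less inhibition of growth, a higher number more inhibition of growth at the concentration tested), compound 1 gives 1.61%, so it stands alone at the bottom of what has been measured. Compound 2 `O=C(CCCCC(S)CCS)Nc1ccc(Cl)cc1`, which carries a chlorophenyl amide of its own, returns in this assay only the verdict "not active" (no number reported) and no number, so nothing can be ordered against it. Compound 3 `CC(=O)SCCC(CCCCC(=O)Nc1cccc(Cl)c1)SC(C)=O` is the next entry, and it differs from compound 1 in one respect: (3-chlorophenyl)amino in place of hydroxy on a carbonyl carbon. Going by the values given here, no measured pair shows what such a change does here. Given that compound 1 gives 1.61% and compound 2 with a related amide is also reported inactive, compound 3 is expected to show only a step within the usual scatter, a number 3.4 percentage points higher from compound 1 to compound 3 (within the scatter), in either direction. Compound 3 is therefore estimated at 5% in this assay, within a range of -5% to 18%.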

Compound 3, percent growth inhibition at one concentration: "not active" (no number reported)
No number was reported for compound 3; there is nothing to compare the estimate with.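

For the compounds shown here, compound 3, like compound 2, returned only the verdict "not active" in this assay, so no step from compound 1 can be read. Nothing shown here accounts for that verdict. The compounds shown leave open how (3-chlorophenyl)amino in place of hydroxy changes growth inhibition.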